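The compounds below may be only part of what the source reports. "The series", "measured", "known", "first", "only" and "open" are said of these compounds alone.

In an assay on CHO cells for displacement of a labelled ligand from adenosine receptor A1 (Homo sapiens), read by scintillation counting, with a stated time of 120 min, tested at 10 uM (a lower number here means less inhibition, a higher number more inhibition at the concentration tested (going by the name of the read-out)), compound 3 `Nc1scc(CN2CCN(c3c(F)cccc3F)CC2)c1C(=O)c1ccc(Cl)cc1` gives 1%. Compound 2 `Nc1scc(CN2CCN(c3ccc([N+](=O)[O-])cc3)CC2)c1C(=O)c1ccc(Cl)cc1` gives 1% and compound 1 `Nc1scc(CN2CCN(c3ccc(Cl)cc3F)CC2)c1C(=O)c1ccc(Cl)cc1` gives 0%; compound 3 and compound 2 stand level at the digits shown, and the step of a number 1 percentage points higher from compound 1 to compound 3 (within the scatter), the step of no change at the digits printed from compound 2 to compound 3 (within the scatter) and the step of a number 1 percentage points higher from compound 1 to compound 2 (within the scatter) all stay within the scatter. Compound 4 `Nc1scc(CN2CCN(c3cccc(F)c3F)CC2)c1C(=O)c1ccc(Cl)cc1` differs from compound 3 by 2,3-difluorophenyl in place of 2,6-difluorophenyl on an amine nitrogen in a ring. Every measured step exchanges the ring on the amine nitrogen in the ring, and none of them moved the read-out beyond the scatter, so for this exchange no step beyond the scatter is expected in either direction. Compound 4 is therefore expected to give 1% in this assay, within -5% to 8%, which is an estimated step of no change at the digits printed from compound 3 to compound 4 (within the scatter).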

Compound 4, a percentage reported as inhibition, at one concentration (the size of the read-out at that concentration, not a potency): 0%
The estimate for compound 4 lay 1 percentage points above the measured number; the measured number falls inside the stated range.
By their numbers in this assay, from the lowest: compounds 1, 4, 2 and 3 (each within the scatter of the next).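

Exchanging 2,6-difluorophenyl for 2,3-difluorophenyl, with the same atoms joined differently on the amine nitrogen in a ring, gives a step within the scatter in this assay (a number 1 percentage points lower from compound 3 to compound 4 (within the scatter)). The two exchanges from the other aryl groups also stay within the scatter (a number 1 percentage points lower from compound 2 to compound 4 (within the scatter); no change at the digits printed from compound 1 to compound 4 (within the scatter)), so fluorine placement on this ring adds no readable difference to the earlier exchanges. No measurement here offers an explanation for these readings.

Still open, from the compounds shown here alone, is whether a non-phenyl group on that nitrogen, such as benzyl or acetyl, would move the read-out beyond the scatter. A carboxylic acid or an amine on the phenyl ring is equally untested by these compounds.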